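The compounds below may be only part of what the source reports. "The series", "measured", "known", "first", "only" and "open" are said of these compounds alone.

Working notes on the series. Three compounds have numbers in a functional assay on MGC-803 cells (Homo sapiens) for antiproliferative activity, read by MTT assay, with a stated time of 72 h; on this read-out higher numbers stand for weaker inhibition and lower numbers for stronger inhibition. Compound 1 `CCCSc1nc(N/N=C/c2cccnc2)c2nnn(Cc3ccccc3)c2n1` gives 38100 nM, compound 2 `CCCSc1nc(N/N=C(\C)c2ccccc2O)c2nnn(Cc3ccc(O)cc3)c2n1` gives 7680 nM, and compound 3 `C#CCSc1nc(N/N=C/c2c(O)ccc3ccccc23)c2nnn(Cc3ccccc3)c2n1` gives 10500 nM. Compound 1 stands at the highest number of the three; compounds 3 and 2 both sit lower, and each gap lies beyond the usual scatter. Compound 4 `CCCSc1nc(N/N=C(\C)c2ccc(Br)cc2)c2nnn(Cc3ccccc3)c2n1` is not yet measured. Relative to compound 1 the change is a group of 10 heavy atoms (8 carbon, 1 nitrogen, 1 bromine; one six-membered aromatic ring of carbon only) in place of a group of 8 heavy atoms (6 carbon, 2 nitrogen; one six-membered aromatic ring with 1 hetero atom), on a nitrogen on an aromatic ring. Among the measured compounds shown here, no measured pair isolates this change, so the expectation rests only on compounds 2 and 3 giving lower numbers than compound 1 in this assay. The step from compound 1 to compound 4 is expected to be a 2.4-fold lower number from compound 1 to compound 4 (0.38 log units; beyond the scatter), a modest fall. Compound 4 is estimated at 16000 nM, within 5000 nM to 45000 nM.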

Compound 4, half-maximal inhibitory concentration: 6020 nM
Beside the measured number, compound 4's estimate is 2.7-fold (0.42 log units) above it; the measured number falls inside the stated range.
By their numbers in this assay, from the lowest: compounds 4, 2 and 3 (each within the scatter of the next); then compound 1.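

In this assay, among the compounds shown here, the change on a nitrogen on an aromatic ring gives a 6.3-fold lower number from compound 1 to compound 4 (0.80 log units; beyond the scatter) and provides the first measured pair that differs in one place. It shows that this position is sensitive to the exchange of the group with a six-membered aromatic ring with 1 hetero atom for the bromine-bearing group with a six-membered aromatic ring of carbon only. No measured evidence bears on the origin of this step. The compounds shown leave open whether the bromine or the rest of the entering group carries the step. They also leave open how an amine or a carboxylic acid in place of the bromine would read.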